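Two limits and a swap of halogens

The source may hold more compounds than are shown below. What is called first, only, known or untested is meant among the compounds shown, and "the series" means these compounds.

Compound 1 `O=S(=O)(CCC(F)(F)C(F)(F)F)c1nc(-c2ccccc2)c(-c2ccccc2)[nH]1`: > 130 mg/kg (a limit)
Compound 2 `CS(=O)(=O)c1nc(-c2ccc(F)cc2)c(-c2ccc(C(F)(F)F)cc2)[nH]1`: > 130 mg/kg (a limit)

In a functional assay on the whole organism with Mus musculus as the target, in the writhing test (on this read-out higher numbers stand for an effect only at larger amounts of compound and lower numbers for an effect already at smaller amounts), compound 2 gives > 130 mg/kg as a limit of the assay and not a number. Going by these compounds, compound 2 thus stands at the limit of > 130 mg/kg in this assay, at which 2 of the 2 values shown sit, and so its actual dose for half-maximal effect remains unknown. The two measured compounds also differ in more than one place, so they offer no single-change comparison.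

Compound 3 `CS(=O)(=O)c1nc(-c2ccc(Cl)cc2)c(-c2ccc(C(F)(F)F)cc2)[nH]1` differs from compound 2 in one place. The change chloro in place of fluoro on an aromatic carbon turns 4-fluorophenyl into 4-chlorophenyl, with chloro in place of fluoro on an aromatic carbon. Among the compounds with values here, no measured pair shows what this swap does in this assay and so no shift beyond the usual scatter is expected, in either direction. Compound 3 may well be reported only as a limit too. The estimated change is a number no higher from compound 2 to compound 3 (the limit leaves the size open) and it is expected to stay within the scatter. For compound 3 the expected value is 130 mg/kg with an estimated range from 60 mg/kg to 260 mg/kg as the likely span.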

Compound 3, dose for half-maximal effect: > 135 mg/kg
Compound 3 gave a limit, no number (the forecaster's own chance of this, stated with the estimate: 65%); middle value at least 1.0-fold (0.01 log units) away from the limit.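

In this assay compound 3 gives > 135 mg/kg, a limit of the assay and not a number. Compound 2 also stands only as a limit, and the step between compound 2 and compound 3 cannot be read. The compounds shown leave open the actual dose for half-maximal effect of each, and whether chloro in place of fluoro changes it.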